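This account rests on a few compounds, and the source may have more. Where it says the series, first, only, none or still open, it means among the compounds named here.

Measured compounds:
compound 1, `CS(=O)(=O)Nc1ccc(-c2nc3ccccc3o2)cc1` — in an assay on cells for inhibition of HSP60/HSP10 (Homo sapiens), with a stated time of 60 min (a higher number here means a weaker inhibitor, a lower number a stronger inhibitor), compound 1 gives > 100000 nM, which is a limit of the assay and not a number.
compound 2, `O=S(=O)(Nc1ccc(-c2nc3ccccc3o2)cc1)c1ccccc1O` — in this assay compound 2 gives > 100000 nM, likewise a limit and not a number.

Going by the values given here, compound 2 therefore stands at the limit, together with the only other measured value (the limit of > 100000 nM in this assay, at which 2 of the 2 values shown sit). Among the compounds with values here, the one measured step, a step that the two limits leave unreadable from compound 1 to compound 2, cannot be read from two limits, so its size and direction stay unknown.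

Compound 3, `COc1ccccc1S(=O)(=O)Nc1ccc(-c2nc3ccccc3o2)cc1`, differs from compound 2 by methyl in place of hydrogen on an oxygen on an aromatic ring. Within the data shown here, no readable measured step bears on this change; the series so far gives only limits, so no direction can be read for it. Compound 3 is expected to sit at the limit as well, with the step of a number no higher from compound 2 to compound 3 (the limit leaves the size open) expected to be none beyond the scatter.

Estimate for compound 3 in this assay: 100000 nM, expected range 30000 nM to 300000 nM.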

Compound 3, half-maximal inhibitory concentration: > 100000 nM
Compound 3 was reported as a limit; the forecaster's own chance of this, stated with the estimate: 85%; the middle value lies on the limit itself.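

In this assay compound 3 gives > 100000 nM as a limit and not a number. Going by these compounds alone, no step among compound 1, compound 2 and compound 3 can be read, since all three stand at one limit: the limit of > 100000 nM in this assay, at which 3 of the 3 values shown sit.

The compounds shown leave open whether any change to the shared core or the group on the sulfonyl sulfur gives a readable value in this assay at all.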